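Hydroxy to chloro, starting from a cytotoxicity limit

The compounds below may be only part of what the source reports. "The series", "measured", "known", "first", "only" and "open" are said of these compounds alone.

Compound 1 `O=C(Nc1ccc(O)c(-c2nc3ccccc3s2)c1)c1cc([N+](=O)[O-])ccc1Cl`: > 25000 nM, a limit
Compound 2 `Cc1cc(NC(=O)c2cc([N+](=O)[O-])ccc2Cl)cc(-c2nc3ccccc3s2)c1O`: > 25000 nM, a limit
Compound 3 `O=C(Nc1nc(-c2cccc(F)c2)cs1)c1cc([N+](=O)[O-])ccc1Cl`: 11000 nM

All three compounds were tested in an ADME assay on Raji cells (Homo sapiens) for cytotoxicity, with a stated time of 72 h; on this read-out lower numbers stand for an effect already at smaller amounts and higher numbers for an effect only at larger amounts of compound. Compound 1 gives > 25000 nM, which is a limit and not a number. Its place is therefore (the limit of > 25000 nM in this assay, at which 2 of the 3 values shown sit).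

Compound 4 `O=C(Nc1ccc(Cl)c(-c2nc3ccccc3s2)c1)c1cc([N+](=O)[O-])ccc1Cl` has not been measured. It differs from compound 1 by a single change, chloro in place of hydroxy on an aromatic carbon, ortho to a 1,3-benzothiazol-2-yl group (chloro in place of hydroxy on an aromatic carbon).

Among the compounds with values here, the only measured step on the core of compound 1 is a step that the two limits leave unreadable from compound 1 to compound 2. It is a different change, methyl in place of hydrogen on an aromatic carbon, and it offers no size to carry over. Compound 3, which has another core, gives 11000 nM, so a number can be obtained in this assay. Within the data shown here, no measured step fixes the size or direction of this change, so the expectation is loose: a modest shift towards smaller amounts, with a real chance that the result is again a limit. The expected step is an at least 1.2-fold lower number from compound 1 to compound 4 (0.09 log units; that floor lies within the scatter). For compound 4 the estimate is 20000 nM, with an expected range from 8000 nM to 40000 nM.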

Compound 4, half-maximal effective concentration: > 25000 nM
Compound 4 gave a limit, no number (the forecaster's own chance of this, stated with the estimate: 55%); middle value at least 1.2-fold (0.09 log units) from the limit.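

In this assay compound 4 gives > 25000 nM, a limit and not a number. Within the data shown here, compound 1 also stands at a limit, so no step from compound 1 to compound 4 can be read, in size or in direction: the limit of > 25000 nM in this assay, at which 3 of the 4 values shown sit. The compounds shown leave open whether chloro in place of hydroxy changes the result on this core at all.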